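The compounds below may be only part of what the source reports. "The series", "measured", "known", "first", "only" and "open" are said of these compounds alone.

Among the compounds with values here, compound 1 `CCCSc1nc2nc(C)cc(N3CC[C@@H](C)[C@@H](N(C)c4ncnc5[nH]ccc45)C3)n2n1` is one of two compounds measured in a functional assay on MGC-803 cells (Homo sapiens) for inhibition, read by MTT assay, with a stated time of 72 h; on this read-out higher numbers stand for weaker inhibition and lower numbers for stronger inhibition. In this assay compound 1 gives 15500 nM. Compound 2 `Cc1cc(N2CC[C@@H](C)[C@@H](N(C)c3ncnc4[nH]ccc34)C2)n2nc(SCc3nc4ccccc4[nH]3)nc2n1` gives 21200 nM in this assay, and the two numbers lie within the scatter of each other, the step being a 1.4-fold higher number from compound 1 to compound 2 (0.14 log units; within the scatter). Compound 3 `Cc1cc(N2CC[C@@H](C)[C@@H](N(C)c3ncnc4[nH]ccc34)C2)n2nc(SCc3ccccc3)nc2n1` has not been measured; it differs from compound 1 by phenyl in place of ethyl on a saturated chain carbon bound to a sulfur. Within the data shown here, because the only comparable measured step was a 1.4-fold higher number from compound 1 to compound 2 (0.14 log units; within the scatter), no step beyond the scatter is expected for compound 3. Compound 3 is therefore estimated at 17000 nM, with a range from 6000 nM to 45000 nM, meaning an expected step of a 1.1-fold higher number from compound 1 to compound 3 (0.04 log units; within the scatter).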

Compound 3, half-maximal inhibitory concentration: 5870 nM
For compound 3 the middle estimate is 2.9-fold (0.46 log units) above the measured one; measured number below the stated range.
By their numbers in this assay, from the lowest: compound 3; then compounds 1 and 2 (each within the scatter of the next).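

Within the data shown here, at this place, on a saturated chain carbon bound to a sulfur, the group can change the number: in this assay, phenyl in place of ethyl gives a 2.6-fold lower number from compound 1 to compound 3 (0.42 log units; beyond the scatter) and is the first step here beyond the scatter. Phenyl in place of 1H-benzimidazol-2-yl gives a 3.6-fold lower number from compound 2 to compound 3 (0.56 log units; beyond the scatter) and shows that two ring-bearing groups can differ here, so having a ring at this place does not alone set the number. No measured evidence here explains either step.

Still open, on these data alone, is how a cyclohexyl or a pyridyl group would read at this place. Also open, as far as these compounds go, is what an amine or a carboxylic acid on the phenyl would do.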